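The compounds below may be only part of what the source reports. "The series", "measured", "known", "first", "only" and "open" are said of these compounds alone.

In a functional assay on B16-F0 cells (Mus musculus) for inhibition, read by CCK-8 assay, with a stated time of 48 h (on this read-out higher numbers stand for weaker inhibition and lower numbers for stronger inhibition), the measured compounds are:

- Compound 1 `COc1cc(-c2ccnc3cc(-c4cccc(C#N)c4)nn23)cc(OC)c1OC`: > 10000 nM, a limit of the assay and not a number
- Compound 2 `COc1cc(-c2ccnc3cc(-c4ccc(C(C)=O)cc4)nn23)cc(OC)c1OC`: 3930 nM

Within the data shown here, compound 2, at 3930 nM, holds the only true number so far. For compound 1 there is only (the limit of > 10000 nM in this assay, at which 1 of the 2 values shown sits).

Compound 3 `COc1ccc(-c2cc3nccc(-c4cc(OC)c(OC)c(OC)c4)n3n2)cc1` keeps the shared core of compound 2 and changes one group: methoxy in place of acetyl on an aromatic carbon. This places methoxy in place of acetyl on an aromatic carbon, para to a large group.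

Among the measured compounds shown here, one measured step bears on this change: an at least 2.5-fold lower number from compound 1 to compound 2 (0.40 log units; beyond the scatter). Going by these compounds, it also exchanges a group on an aromatic ring, but its full size remains unknown since it starts from a limit. For the measured compounds named here, it shows only that such a swap can move the number beyond the scatter. On that thin basis, a 4.4-fold lower number from compound 2 to compound 3 (0.64 log units; beyond the scatter) is expected, tentatively towards stronger inhibition in this assay. The estimated value for compound 3 is 900 nM, with an expected range from 80 nM to 7000 nM.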

Compound 3, half-maximal inhibitory concentration: 1410 nM
Estimate against measurement, compound 3: 1.6-fold (0.19 log units) below, and the stated range covers the measured number.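

Among these compounds, replacing acetyl with methoxy on the aromatic carbon para to a large group gives, in this assay, a 2.8-fold lower number from compound 2 to compound 3 (0.45 log units; beyond the scatter), the first step here with true numbers at both ends and so the first whose size is known. Compound 1 remains a limit of the assay and not a number: the limit of > 10000 nM in this assay, at which 1 of the 3 values shown sits. Going by these compounds, the swap of 3-cyanophenyl for 4-methoxyphenyl therefore reads only as an at least 7.0-fold lower number from compound 1 to compound 3 (0.85 log units; beyond the scatter), and its true size stays unknown.

On these data alone, only acetyl and methoxy can be compared by true numbers here, so it remains open how an amine, a carboxylic acid or a longer chain such as butoxy would behave on this carbon. The compounds shown also cannot separate what the carbonyl double bond contributes from what the size of the group contributes.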